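This account rests on a few compounds, and the source may have more. Where it says the series, first, only, none or still open, it means among the compounds named here.

Compound 1 `CC(C)OC(=O)COC(=O)c1ccc([N+](=O)[O-])o1`: > 100000 nM
Compound 2 `CC(C)(C)N(CCCc1ccccc1)C(=O)COC(=O)c1ccc([N+](=O)[O-])o1`: "not active" (no number reported)

Both compounds were tested in an ADME assay on MT4 cells (Homo sapiens) for cytotoxicity, read by MTT assay, with a stated time of 3 days; on this read-out lower numbers stand for higher toxicity in this test and higher numbers for lower toxicity in this test. Compound 1 gives > 100000 nM, which is a limit of the assay and not a number. Compound 2 is reported only as "not active" (no number reported), so it has no exact place on the scale.

Compound 3 `COc1ccc(CN(C(=O)COC(=O)c2ccc([N+](=O)[O-])o2)C(C)(C)C)cc1` carries 4-methoxyphenyl in place of phenethyl on a saturated chain carbon bound to an amide-type nitrogen. Cut one bond further out, the same change reads 3-phenylpropyl to 4-methoxybenzyl. For the measured compounds named here, no measured step shows what this change does in this assay, so no shift beyond the usual scatter is expected in either direction. The expectation of low toxicity leans on compound 1 with its limit of > 100000 nM. The expected value for compound 3 is estimated at 50000 nM, with a range from 15000 nM to 100000 nM.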

Compound 3, half-maximal cytotoxic concentration: > 100000 nM
Compound 3: a limit, no number; the forecaster's own chance of this, stated with the estimate: 55%; middle value at least 2.0-fold (0.30 log units) from the limit.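

No step can be read between compound 2 and compound 3 in this assay, since neither has an exact number: compound 3 gives > 100000 nM, which is a limit and not a number. The compounds shown leave open what exchanging 3-phenylpropyl for 4-methoxybenzyl does in this assay.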